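A few compounds are considered here, and "the series" means these few. Any claim that something is new, unique, unknown or untested is made for them only; others in the source may bear on it.

Measured so far:
- Compound 1, `CNc1nc(NC2(C#N)CCCCC2)nc(-n2ccnc2)n1`: in an in vitro assay on Sf21 cells for inhibition of high affinity 3',5'-cyclic-AMP phosphodiesterase 7A (Homo sapiens) (a lower number here means a stronger inhibitor, a higher number a weaker inhibitor), compound 1 gives 1050 nM.
- Compound 2, `CNc1nc(NC2(C#N)CCCCC2)nc(N2CCCC2)n1`: compound 2 reaches only the limit of the assay, > 5000 nM.
- Compound 3, `CNc1nc(NC2(C#N)CCCCC2)nc(-n2cnc3ccccc32)n1`: compound 3 also reaches only a limit, > 1000 nM.

Among these three, compound 1 is the only one with a real number; the other two sit at limits, one at the limit of > 1000 nM in this assay, at which 1 of the 3 values shown sits, and one at the limit of > 5000 nM in this assay, at which 1 of the 3 values shown sits. Within the data shown here, the single measured step that can be compared is an at least 4.7-fold higher number from compound 1 to compound 2 (0.67 log units; beyond the scatter), a clear weakening when the 1H-imidazol-1-yl group is exchanged.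

Compound 4, `CNc1nc(NC2(C#N)CCCCC2)nc(SC)n1`, is not yet measured. It differs from compound 1 in one place: methylsulfanyl in place of 1H-imidazol-1-yl on an aromatic carbon. Among the measured compounds shown here, the change again removes the 1H-imidazol-1-yl group from the same position, and the one step that bears on such a removal, an at least 4.7-fold higher number from compound 1 to compound 2 (0.67 log units; beyond the scatter), went toward weaker inhibition and beyond the scatter. Compound 3, which carries a different ring at that position, also ended at a limit. On this basis the expectation for compound 4 is a weaker inhibitor than compound 1, with a 3.8-fold higher number from compound 1 to compound 4 (0.58 log units; beyond the scatter). Compound 4 is therefore estimated at 4000 nM, most likely between 1500 nM and 10000 nM, with a fair chance that only a limit is reported.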

Compound 4, half-maximal inhibitory concentration: 46 nM
For compound 4 the middle estimate is 87-fold (1.94 log units) above the measured one; measured number below the stated range.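

In this assay, this result shows that the position on the aromatic carbon opposite the ring nitrogen does not depend on keeping the 1H-imidazol-1-yl group or any ring: methylsulfanyl, which has no ring and fewer heavy atoms, gives a 23-fold lower number from compound 1 to compound 4 (1.36 log units; beyond the scatter). The earlier compounds shown here showed only weakening or limits at this position, whereas the new value shows that the identity of the replacing group decides the outcome, since exchanging pyrrolidin-1-yl for methylsulfanyl at the same place gives an at least 100-fold lower number from compound 2 to compound 4 (2.03 log units; beyond the scatter). Compound 2 stands at a limit of the assay rather than at a number, so the size of that second step is a lower bound: the limit of > 5000 nM in this assay, at which 1 of the 4 values shown sits.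

Nothing shown here explains why methylsulfanyl does so much better than the other groups at this position. From the compounds shown here alone, it also remains open whether the sulfur atom or simply the short chain matters, a question that a methoxy group, a longer ethylsulfanyl chain or a small amine such as dimethylamino at the same carbon could help to answer.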